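The source may hold more compounds than are shown below. What is called first, only, known or untested is meant among the compounds shown, and "the series" means these compounds.

In a functional assay on MCF7 cells (Homo sapiens) for inhibition, read by MTT assay (a higher number here means a weaker inhibitor of growth, a lower number a stronger inhibitor of growth), compound 2 (`COc1cc2oc(-c3cccc(NC(=O)c4ccc(Br)cc4)c3)cc(=O)c2c(OC)c1OC`) gives 9650 nM and sits level, within the scatter, with compound 1 (`COc1cc2oc(-c3cccc(NC(=O)c4ccccc4)c3)cc(=O)c2c(OC)c1OC`) at 12100 nM in that read-out, while compound 3 (`COc1cc2oc(-c3cccc(NC(=O)c4ccccc4Br)c3)cc(=O)c2c(OC)c1OC`) at 55000 nM lies clearly higher. Compound 4 (`COc1cc2oc(-c3cccc(NC(=O)c4ccc(F)cc4)c3)cc(=O)c2c(OC)c1OC`) differs from compound 2 in one place (fluoro in place of bromo on an aromatic carbon): fluoro in place of bromo on an aromatic carbon, para to a large group. Bromo in place of hydrogen at that spot is the closest evidence, and the step (a 1.3-fold lower number from compound 1 to compound 2 (0.10 log units; within the scatter)) stays within the scatter. The larger steps (a 4.5-fold higher number from compound 1 to compound 3 (0.66 log units; beyond the scatter) and a 5.7-fold higher number from compound 2 to compound 3 (0.76 log units; beyond the scatter)) both end at the 2-bromophenyl group, which compound 4 lacks. So no step beyond the scatter is expected in this assay for this swap. The estimated step (a 1.1-fold higher number from compound 2 to compound 4 (0.06 log units; within the scatter)) stays small. Compound 4 is expected at 11000 nM with a likely range from 5500 nM to 22000 nM in this estimate.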

Compound 4, concentration for 50% growth inhibition: 14700 nM
Compound 4: the middle estimate sits 1.3-fold (0.13 log units) below what was measured; the range from low to high includes it.
By their numbers in this assay, from the lowest: compounds 2, 1 and 4 (each within the scatter of the next); then compound 3.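

In this assay, a second halogen at this spot, para to a large group, still gives no step beyond the scatter: a 1.5-fold higher number from compound 2 to compound 4 (0.18 log units; within the scatter) and a 1.2-fold higher number from compound 1 to compound 4 (0.08 log units; within the scatter) leave hydrogen, bromo and fluoro level here. The 2-bromophenyl compound remains the one that stands apart, with a 3.7-fold lower number from compound 3 to compound 4 (0.57 log units; beyond the scatter) as its step. No measurement here accounts for these numbers. Open, on these data alone, is whether an amine or a carboxylic acid in place of the halogen on this ring would move the number beyond the scatter.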